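The source may report more compounds than this note shows. Statements on the series, on what has been measured and on what is new or still open speak of the compounds shown alone.

Among the compounds with values here, compound 2 `NCC(=O)NS(=O)(=O)c1ccc(Nc2nc(N)n(C(=O)c3c(F)cccc3F)n2)cc1` gives 9450 nM in a functional assay on A-375 cells (Homo sapiens) for antiproliferative activity (a lower number here means a stronger inhibitor, a higher number a weaker inhibitor), the lowest of the two numbers so far; compound 1 `Nc1nc(Nc2ccc(S(=O)(=O)NC(=O)CCC(=O)O)cc2)nn1C(=O)c1c(F)cccc1F` gives 20300 nM. Within the data shown here, the only measured step, a 2.1-fold lower number from compound 1 to compound 2 (0.33 log units; beyond the scatter), concerns a different exchange on the same chain carbon. Compound 3 `COCCOCC(=O)NS(=O)(=O)c1ccc(Nc2nc(N)n(C(=O)c3c(F)cccc3F)n2)cc1` differs from compound 2 by 2-methoxyethoxy in place of amino on a saturated chain carbon bound to a carbonyl carbon. Among the measured compounds shown here, no measured step covers this exchange, so no direction is indicated; a step of roughly the size of a 2.1-fold lower number from compound 1 to compound 2 (0.33 log units; beyond the scatter) either way would fit, and nothing beyond the scatter is expected. Compound 3 is expected at 10000 nM in this assay, with a range of 4000 nM to 25000 nM, meaning a 1.1-fold higher number from compound 2 to compound 3 (0.02 log units; within the scatter).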

Compound 3, half-maximal inhibitory concentration in the A-375 assay: > 100000 nM
Compound 3 gave a limit, no number (the forecaster's own chance of this, stated with the estimate: 15%); middle value at least 10-fold (1.00 log units) from the limit.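

In the A-375 assay compound 3 gives a limit, not a number: the limit of > 100000 nM in the A-375 assay, at which 1 of the 3 values shown sits. In the A-375 assay the saturated chain carbon bound to a carbonyl carbon proves far more sensitive than the earlier exchange showed, with 2-methoxyethoxy in place of amino giving an at least 10-fold higher number from compound 2 to compound 3 (1.02 log units; beyond the scatter), and in place of carboxymethyl giving an at least 4.9-fold higher number from compound 1 to compound 3 (0.69 log units; beyond the scatter). In a physicochemical assay for solubility, at pH 7.4 (a lower number here means a less soluble compound, a higher number a more soluble compound), compound 2 gives 200 ug/mL. In the physicochemical assay compound 3 gives > 1000 ug/mL as a limit, not a number: the limit of > 1000 ug/mL in the physicochemical assay, at which 1 of the 2 values shown sits. In the physicochemical assay the exchange from amino gives an at least 5.0-fold higher number from compound 2 to compound 3 (0.69 log units; beyond the scatter), also against a limit.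

Going by these compounds, whether the ether oxygens or the chain length matters stays open; a methoxy group or a dimethylamine at this carbon would separate the two. On these data alone, the actual values of compound 3 also stay open in both read-outs.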